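From Pentan-3-yl to Neopentyl at the Assay Limit

The compounds below may be only part of what the source reports. "The series", "measured", "known", "first", "only" and "open" are said of these compounds alone.

In an ADME assay on MT4 cells (Homo sapiens) for cytotoxicity, read by MTT assay, with a stated time of 5 days (a lower number here means that less compound is tolerated, a higher number that more compound is tolerated), compound 1 `CCC(C)Nc1cc(Oc2c(OC)cc3cc(C#N)ccc3c2OC)nc(Nc2ccc(C#N)cc2)n1` gives > 125000 nM, which is a limit and not a number. Compound 2 `CCC(CC)Nc1cc(Oc2c(OC)cc3cc(C#N)ccc3c2OC)nc(Nc2ccc(C#N)cc2)n1` gives > 125000 nM, which is also a limit. The whole record so far is therefore (the limit of > 125000 nM in this assay, at which 2 of the 2 values shown sit), and compound 2 has no readable number to start from.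

Compound 3 `COc1cc2cc(C#N)ccc2c(OC)c1Oc1cc(NCC(C)(C)C)nc(Nc2ccc(C#N)cc2)n1` keeps the shared core and alters only the chain on the nitrogen, with neopentyl in place of pentan-3-yl on a nitrogen on an aromatic ring. The two chains hold the same atoms, joined differently.

Within the data shown here, only one measured step bears on this change, and it too alters that chain: a step that the two limits leave unreadable from compound 1 to compound 2. With no readable size, it gives no guide to direction, so no change beyond the usual scatter is expected in this assay. The expected change is an at least 1.0-fold lower number from compound 2 to compound 3 (0.01 log units; that floor lies within the scatter). The value for compound 3 is estimated at 120000 nM, with an expected range of 60000 nM to 250000 nM.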

Compound 3, half-maximal cytotoxic concentration: > 125000 nM
Compound 3: no number, only a limit (the forecaster's own chance of this, stated with the estimate: 75%); at least 1.0-fold (0.01 log units) between middle value and limit.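

In this assay, compound 3 also gives a limit and not a number, so no step can be read among compound 1, compound 2 and compound 3: the limit of > 125000 nM in this assay, at which 3 of the 3 values shown sit.

The compounds shown leave open how the sec-butyl, pentan-3-yl and neopentyl chains truly compare in this assay, and at what concentration, if any, each compound would harm the cells.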